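Benzyl-protected series: effect of a longer chain on compound 3

The source may hold more compounds than are shown below. What is called first, only, known or untested is meant among the compounds shown, and "the series" means these compounds.

Measured in a functional assay on HeLa cells (Homo sapiens) for antiproliferative activity, read by sulforhodamine B assay; a higher number here means a weaker inhibitor of growth, a lower number a stronger inhibitor of growth:
- Compound 1 `CCC[C@H]1O[C@H](COCc2ccccc2)[C@@H](OCc2ccccc2)[C@H](OCc2ccccc2)[C@H]1O` gives 17400 nM
- Compound 2 `ClC1(Cl)[C@@H]2[C@@H](OCc3ccccc3)[C@H](OCc3ccccc3)[C@@H](COCc3ccccc3)O[C@@H]21` gives > 50000 nM (a limit)
- Compound 3 `C[C@@H]1O[C@H](COCc2ccccc2)[C@@H](OCc2ccccc2)[C@H](OCc2ccccc2)C1=O` gives > 50000 nM (a limit)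

Compound 3 has no number, only the limit. Two of the three compounds sit there: the limit of > 50000 nM in this assay, at which 2 of the 3 values shown sit. Compound 4 `CCCCC[C@@H]1O[C@H](COCc2ccccc2)[C@@H](OCc2ccccc2)[C@H](OCc2ccccc2)C1=O` differs from compound 3 by butyl in place of hydrogen on a saturated chain carbon bound to a saturated ring carbon, or methyl to pentyl when cut one bond further out.

Among the compounds with values here, no measured step covers this change. Within the data shown here, compound 1 gives 17400 nM, the only number in the set, and it also carries a saturated chain, though it differs from compound 4 elsewhere too. On that slim basis, a modest move towards stronger growth inhibition in this assay is expected, and compound 4 may still reach the limit. The estimate corresponds to an expected at least 1.6-fold lower number from compound 3 to compound 4 (0.22 log units; that floor lies within the scatter). Compound 4 is estimated at 30000 nM, with an expected range of 12000 nM to 50000 nM.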

Compound 4, concentration for 50% growth inhibition: > 50000 nM
Compound 4: no number, only a limit; the forecaster's own chance of this, stated with the estimate: 45%; at least 1.6-fold (0.22 log units) between middle value and limit.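

Compound 3 and compound 4 each carry only a limit, so no step can be read between them: the limit of > 50000 nM in this assay, at which 3 of the 4 values shown sit. As far as these compounds go, whether butyl in place of hydrogen on a saturated chain carbon bound to a saturated ring carbon changes growth inhibition at all remains open.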